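The source may report more compounds than this note shows. Statements on the series, on what has been measured and on what is new or still open speak of the compounds shown alone.

Measured so far in a functional assay on PC-3 cells (Homo sapiens) for antiproliferative activity, read by MTT assay, with a stated time of 48 h; a lower number here means a stronger inhibitor, a higher number a weaker inhibitor:
compound 1 `COc1cc(/C=C/C(C)=O)ccc1OCc1cn(-c2c(Cl)cccc2Cl)nn1` gives 3070 nM;
compound 2 `COc1cc(/C=C/C(C)=O)ccc1OCc1cn(-c2ccc(NC(=O)c3ccccc3)cc2)nn1` gives 76800 nM;
compound 3 `CCOC(=O)c1ccc(-n2cc(COc3ccc(/C=C/C(C)=O)cc3OC)nn2)cc1` gives 59200 nM.

Compound 3 stands second highest of these three numbers, closest to compound 2 and far from compound 1. Compound 4 `COc1cc(/C=C/C(C)=O)ccc1OCc1cn(-c2ccccc2)nn1` differs from compound 3 by hydrogen in place of ethoxycarbonyl on an aromatic carbon. Among the measured compounds shown here, the one measured step at that aromatic carbon, a 1.3-fold lower number from compound 2 to compound 3 (0.11 log units; within the scatter), shows that exchanging one group for another there left the number unchanged within the scatter. For the measured compounds named here, no measured step removes the group altogether, and compound 1 carries a differently substituted ring with no step connecting it to compound 3, so its much lower number does not bear directly on this change. A small step is therefore expected in this assay, with no clear direction. Compound 4 is estimated at 40000 nM, between 10000 nM and 150000 nM, meaning an expected step of a 1.5-fold lower number from compound 3 to compound 4 (0.17 log units; within the scatter).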

Compound 4, half-maximal inhibitory concentration: 78600 nM
Compound 4: the middle estimate sits 2.0-fold (0.29 log units) below what was measured; low and high end bracket the measured number.
By their numbers in this assay, from the lowest: compound 1; then compounds 3, 2 and 4 (each within the scatter of the next).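

In this assay hydrogen in place of ethoxycarbonyl gives a 1.3-fold higher number from compound 3 to compound 4 (0.12 log units; within the scatter) and hydrogen in place of benzamido gives a 1.0-fold higher number from compound 2 to compound 4 (0.01 log units; within the scatter) so at this carbon the unsubstituted ring reads the same as either substituted one. Phenyl in place of 2,6-dichlorophenyl on the aromatic nitrogen gives a 26-fold higher number from compound 1 to compound 4 (1.41 log units; beyond the scatter) and this large step shows that the number depends on the two chlorines of compound 1 rather than on the groups compared so far. From the compounds shown here alone, whether an amine or a carboxylic acid at that carbon would shift the number stays open. No measurement here explains any of these steps.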